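A few compounds are considered here, and "the series" means these few. Any claim that something is new, unique, unknown or untested is made for them only; others in the source may bear on it.

Compound 1 `Cc1cn2c(-c3cn[nH]c3)cnc2c(Nc2cc(Cc3nccs3)ns2)n1`, compound 2 `Cc1cn2c(-c3cn[nH]c3)cnc2c(Nc2cc(Cc3cccnc3)ns2)n1` and compound 3 `Cc1cn2c(-c3cn[nH]c3)cnc2c(Nc2cc(Cc3ccncc3)ns2)n1` share one core and differ only in the aromatic group carried on the saturated chain carbon bound to an aromatic carbon. In an ADME assay on the whole organism for pharmacokinetics, with Rattus norvegicus as the target, with a stated time of 6 h, at a dose of 10 mg/kg by the oral route (on this read-out higher numbers stand for higher exposure at the dose given and lower numbers for lower exposure), compound 1 gives 1540 ng.h/mL. For compound 2 the read-out is "not determined" (no result reported), and for compound 3 it is likewise "not determined" (no result reported). Among the measured compounds shown here, compound 3 therefore stands without a single number on this read-out, and no step between measured compounds can be drawn around it. Compound 4 `COc1cccc(Cc2cc(Nc3nc(C)cn4c(-c5cn[nH]c5)cnc34)sn2)n1` is the next member and has not yet been measured. It differs from compound 3 in one place: 6-methoxypyridin-2-yl in place of pyridin-4-yl on a saturated chain carbon bound to an aromatic carbon. For the measured compounds named here, with no number for compound 3, the only anchor is compound 1 at 1540 ng.h/mL. No step beyond the scatter is expected in this assay for the move from compound 3 to compound 4, in either direction. Compound 4 is expected to give 1000 ng.h/mL in this assay, within a range from 200 ng.h/mL to 4000 ng.h/mL.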

Compound 4, area under the concentration-time curve: 2300 ng.h/mL
Compound 4: middle estimate off by 2.3-fold (0.36 log units), on the low side; the range from low to high includes it.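

With compound 4, the position on the saturated chain carbon bound to an aromatic carbon yields its first readable comparison in this assay: a 1.5-fold higher number from compound 1 to compound 4 (0.17 log units; within the scatter). Oral exposure therefore stays within the usual scatter when 6-methoxypyridin-2-yl replaces 1,3-thiazol-2-yl, and the shared core keeps a measured exposure with either group in this place, with compound 4 at 2300 ng.h/mL. The steps to compound 2 and compound 3 cannot be read, and nothing available explains the result in terms of cause.

The compounds shown therefore leave open what the methoxy group itself contributes, since the unsubstituted pyridine isomers carry no number on this read-out. They also leave open how this assay would respond to an amine or a carboxylic acid on the pyridine ring in place of methoxy.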